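The compounds below may be only part of what the source reports. "The series", "measured", "known", "first", "only" and "open" are said of these compounds alone.

The measured compounds are:

compound 1, `CC1(CC[C@H](c2ccc(C(=O)NCc3nn[nH]n3)cc2)N2C(=O)C(c3cc(Cl)cc(Cl)c3)=N[C@]23CC[C@@H](C(C)(C)C)CC3)CC1`, 17 nM
compound 2, `C[C@H](c1ccc(C(=O)NCCC(=O)O)cc1)N1C(=O)C(c2cccc(Cl)c2)=N[C@]12CC[C@@H](C(C)(C)C)CC2`, 130 nM
compound 3, `C[C@H](c1ccc(C(=O)NCCC(=O)O)cc1)N1C(=O)C(c2cccc(F)c2)=N[C@]12CC[C@@H](C(C)(C)C)CC2`, 490 nM

All three were tested in an assay on CHO cells for displacement of a labelled ligand from Glucagon receptor (Homo sapiens), read by scintillation counting, with a stated time of 60 min; on this read-out higher numbers stand for weaker inhibition and lower numbers for stronger inhibition. Compound 1 gives the lowest number of the three: compound 2 stands nearest to it, and compound 3 furthest. Compound 4, `CC(C)CC[C@H](c1ccc(C(=O)NCc2nn[nH]n2)cc1)N1C(=O)C(c2cc(Cl)cc(Cl)c2)=N[C@]12CC[C@@H](C(C)(C)C)CC2`, has not yet been measured in this assay. It differs from compound 1 in one place, isopropyl in place of 1-methylcyclopropyl on a saturated chain carbon, three bonds along the chain from an amide-type nitrogen in a ring and an aromatic carbon: a three-membered non-aromatic ring of carbon only leaves and no ring enters, the count of heavy atoms falling from four to three, with no change in hydrogen-bond donors, acceptors or charge.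

Among the compounds with values here, the one measured step, a 3.8-fold higher number from compound 2 to compound 3 (0.58 log units; beyond the scatter), concerns an aromatic substituent on a different part of the shared core and says nothing about the saturated chain carbon changed here. Within the data shown here, no measured pair bears on this change, so the expectation rests on the closeness of the two groups alone. Compound 4 is therefore expected to give 25 nM, within a range of 8 nM to 80 nM. That estimate is expected to mean a 1.5-fold higher number from compound 1 to compound 4 (0.17 log units; within the scatter), a step within the scatter.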

Compound 4, half-maximal inhibitory concentration: 22 nM
Compound 4: middle estimate off by 1.1-fold (0.06 log units), on the high side, within the range that was stated.
By their numbers in this assay, from the lowest: compounds 1 and 4 (each within the scatter of the next); then compound 2; then compound 3.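

In this assay, isopropyl in place of 1-methylcyclopropyl on a saturated chain carbon, three bonds along the chain from an amide-type nitrogen in a ring and an aromatic carbon, gives a 1.3-fold higher number from compound 1 to compound 4 (0.11 log units; within the scatter). The earlier compounds shown here offered no reading at this position, and this one shows that, on the shared core of compound 1, the three-membered ring of carbon only can leave with a step that stays within the scatter. No measurement here accounts for this result.

The compounds shown leave open how this position responds to an amine or a carboxylic acid at the end of the chain, or to a chain longer than isopentyl. They also leave open whether the same exchange reads alike on a different aromatic substitution of the core.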